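Series notes: the step from compound 3 to compound 4

The source may hold more compounds than are shown below. What is called first, only, known or untested is meant among the compounds shown, and "the series" means these compounds.

Measured so far in a functional assay on G-361 cells (Homo sapiens) for inhibition, with a stated time of 72 h; on this read-out lower numbers stand for stronger inhibition and higher numbers for weaker inhibition:
- compound 1 `NC1CCC(Nc2nc(NCc3ccc(Br)cc3)c3ncn(C4CCCC4)c3n2)CC1` (1480 nM)
- compound 2 `NC1CCC(Nc2nc(NCc3ccc(-c4ccco4)cc3)c3ncn(C4CCCC4)c3n2)CC1` (164 nM)
- compound 3 `NC1CCC(Nc2nc(NCc3ccc(-c4ccsc4)nc3)c3ncn(C4CCCC4)c3n2)CC1` (272 nM)

Compound 3 belongs to the lower pair of values. It is level with its partner within the scatter (a 1.7-fold higher number from compound 2 to compound 3 (0.22 log units; within the scatter)) and well under the remaining value (a 5.4-fold lower number from compound 1 to compound 3 (0.74 log units; beyond the scatter)).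

Still unmeasured is compound 4 `NC1CCC(Nc2nc(NCc3cc(Cl)ccc3O)c3ncn(C4CCCC4)c3n2)CC1`, which has 5-chloro-2-hydroxyphenyl in place of 6-(thiophen-3-yl)pyridin-3-yl on a saturated chain carbon bound to a nitrogen on an aromatic ring.

Two measured steps bear on this change, both modest and beyond the scatter: a 9.0-fold lower number from compound 1 to compound 2 (0.96 log units; beyond the scatter) and the step to compound 3 given above. Among these three, the groups with two aromatic rings give the lower numbers, and none goes against this. Compound 4 returns to a single halogen-bearing aromatic ring, as in compound 1 (1480 nM). Among the compounds with values here, the hydroxy group has no measured counterpart, so the size of the reversal stays open. In this assay a modest step to a higher number is therefore expected, probably short of the full return. The estimated step is a 2.9-fold higher number from compound 3 to compound 4 (0.47 log units; beyond the scatter) for this change. For compound 4 the expected value is 800 nM with an estimated range from 250 nM to 2500 nM in this read-out.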

Compound 4, half-maximal inhibitory concentration: 390 nM
The estimate for compound 4 lay 2.1-fold (0.31 log units) above the measured number, within the range that was stated.
By their numbers in this assay, from the lowest: compounds 2, 3 and 4 (each within the scatter of the next, the first and the last beyond it); then compound 1.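

In this assay, a single aromatic ring at this place, on a saturated chain carbon bound to a nitrogen on an aromatic ring, does not by itself bring the number back to that of the bromo compound: a 3.8-fold lower number from compound 1 to compound 4 (0.58 log units; beyond the scatter). The link between two aromatic rings and the lower numbers therefore no longer holds across the series, since compound 4 goes against it: 5-chloro-2-hydroxyphenyl, with one ring and fewer heavy atoms, stands level with the thiophene-bearing pyridine group (a 1.4-fold higher number from compound 3 to compound 4 (0.16 log units; within the scatter)), although a gap to the furan-bearing group remains (a 2.4-fold higher number from compound 2 to compound 4 (0.38 log units; beyond the scatter)). No supporting data bear on why this single-ring group matches compound 3.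

The compounds shown do not separate the share of the hydroxy group from that of the chloro group, as neither appears here without the other on this ring. Also open, from the compounds shown here alone, is whether a methoxy group or an amine in place of the hydroxy group would keep the number near that of compound 4, or would move it toward that of compound 1.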